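The compounds below may be only part of what the source reports. "The series", "measured", "known", "first", "only" and "open" are said of these compounds alone.

In an ADME assay on HEK293 cells (Homo sapiens) for cytotoxicity (a lower number here means a stronger inhibitor, a higher number a weaker inhibitor), compound 1 `CCCCCCCCCCCCCCNC(=O)[C@H](CO)/N=C/c1ccc(Cl)cc1` gives 77700 nM, and compound 2 `CCCCCCCCCCCCCCNC(=O)[C@H](CO)/N=C/c1cccc([N+](=O)[O-])c1` gives 82700 nM. Going by the values given here, these two readings lie within the usual scatter of each other, so compound 2 holds no separate place on this scale, although only two numbers are available to judge it. Compound 3 `CCCCCCCCCCCCCCNC(=O)[C@H](CO)/N=C/c1cccc(Cl)c1` departs from compound 2 at a single site: chloro in place of nitro on an aromatic carbon. This turns 3-nitrophenyl into 3-chlorophenyl, while the rest of the structure stays the same. Among the compounds with values here, only one measured step bears on this change, a 1.1-fold higher number from compound 1 to compound 2 (0.03 log units; within the scatter), where 3-nitrophenyl replaced 4-chlorophenyl and the reading stayed within the scatter. Within the data shown here, that step is small but it is a single comparison, and no measured pair isolates nitro against chloro at the same position. No shift beyond the scatter is therefore expected in this assay. The expected change is a 1.0-fold lower number from compound 2 to compound 3 (0.01 log units; within the scatter), which is an estimate and remains within the scatter. For compound 3 the estimated value is 80000 nM, with an expected range from 45000 nM to 130000 nM.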

Compound 3, half-maximal inhibitory concentration: 77000 nM
Beside the measured number, compound 3's estimate is 1.0-fold (0.02 log units) above it; measured number inside the range.
By their numbers in this assay, from the lowest: compounds 3, 1 and 2 (each within the scatter of the next).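

Placed side by side at the same position in this assay, the two groups give a 1.1-fold lower number from compound 2 to compound 3 (0.03 log units; within the scatter), so replacing nitro with chloro, with its three heavy atoms giving way to one and its two hydrogen-bond acceptors gone, leaves the reading within the scatter. The place of the chloro on the ring can now be read on its own as well: 3-chlorophenyl in place of 4-chlorophenyl gives a 1.0-fold lower number from compound 1 to compound 3 (0.00 log units; within the scatter), and so neither this exchange of groups nor this shift of the chloro separates the three compounds on this scale. Nothing available here speaks to why the readings stay together.

On these data alone, all three compounds carry an electron-neutral count of charge and differ only in a single substituent on the aromatic ring, so it remains open whether an amine or a carboxylic acid at this position would move the reading beyond the scatter. Going by these compounds alone, it is equally open how this assay would respond to a shorter chain on the amide or to a change elsewhere in the shared core, since every step so far leaves those parts untouched.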